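The source may hold more compounds than are shown below. What is called first, only, known or untested is meant among the compounds shown, and "the series" means these compounds.

The study compares four compounds in a functional assay on cells (Melanoma cell, Homo sapiens) for cytotoxicity, read by sulforhodamine B assay, with a stated time of 48 h; on this read-out lower numbers stand for stronger inhibition of growth and higher numbers for weaker inhibition of growth. Compound 1 `COc1ccc(C2CC(c3ccccc3)=NN2C2=NC(=O)/C(=C3\C(=O)Nc4ccccc43)S2)cc1` gives 2000 nM in this assay. Compound 2 `COc1ccc(C2CC(c3ccccc3)=NN2C2=NC(=O)/C(=C3\C(=O)Nc4ccc(Br)cc43)S2)cc1` differs from compound 1 by a single change, (bromo in place of hydrogen on an aromatic carbon), and in this assay compound 2 gives 210 nM. That one exchange produces a 9.5-fold lower number from compound 1 to compound 2 (0.98 log units; beyond the scatter).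

Compound 3 `COc1ccc(C2=NN(C3=NC(=O)/C(=C4\C(=O)Nc5ccccc54)S3)C(c3ccc(Cl)cc3)C2)cc1` is built on a different core; the difference between the two cores is not broken down here. In this assay compound 3 gives 100000 nM, the highest number among the three measured compounds, with its gaps to compound 1 and to compound 2 both beyond the scatter.

Compound 4 `COc1ccc(C2=NN(C3=NC(=O)/C(=C4\C(=O)Nc5ccc(Br)cc54)S3)C(c3ccc(Cl)cc3)C2)cc1` carries the same change on the core of compound 3: bromo in place of hydrogen on an aromatic carbon. The place of the change is the same as in the earlier pair, so the two changes are the same change, now made on a much weaker starting point.

The expected step is a 6.7-fold lower number from compound 3 to compound 4 (0.82 log units; beyond the scatter), resting on the fact that the same change gave a 9.5-fold lower number from compound 1 to compound 2 (0.98 log units; beyond the scatter) on the core of compound 1. Whether that gain transfers fully to the core of compound 3 is not known from these data, so the range is kept wide. Compound 4 is estimated at 15000 nM, with a range from 3000 nM to 100000 nM in this assay.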

Compound 4, concentration for 50% growth inhibition: 160 nM
The estimate for compound 4 lay 94-fold (1.97 log units) above the measured number; the whole stated range lies above it.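

In this assay bromo in place of hydrogen on an aromatic carbon also lowers the number on the core of compound 3, with a 630-fold lower number from compound 3 to compound 4 (2.80 log units; beyond the scatter) in this second pair, so the direction of the step carries over from one core to the other in these two pairs. The size of the step does not carry over, and the two steps stand clearly apart: the same change on two cores in this assay, a 9.5-fold lower number (0.98 log units; beyond the scatter) from compound 1 to compound 2 and a 630-fold lower number (2.80 log units; beyond the scatter) from compound 3 to compound 4, 66-fold (1.82 log units) apart, beyond the scatter of two such steps. Among the compounds shown here, these pairs do not show why the size differs, and with only two cores they give no rule for how large the step would be on a third core, so the gain seen on one core cannot be taken as a measure of the gain on another.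

The compounds shown leave open whether fluoro, an amine or a carboxylic acid at the same place on the aromatic ring would behave like bromo on either core, and so whether the large step on the core of compound 3 belongs to bromo alone. Going by these compounds, whether the two steps hold outside this assay on other kinds of cells also stays open.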